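The source may hold more compounds than are shown below. What is called first, only, known or untested is meant among the compounds shown, and "the series" means these compounds.

Measured compounds in a functional assay on MCF7 cells (Homo sapiens) for cytotoxicity, read by MTT assay, with a stated time of 72 h; on this read-out higher numbers stand for weaker inhibition and lower numbers for stronger inhibition:
compound 1, `Cc1c(CO)c(CO)c2n1[C@@H](c1ccccc1)SC2`, 1000 nM
compound 2, `OCc1cn2c(c1CO)CS[C@@H]2c1ccccc1`, "not determined" (no result reported)
compound 3, `OCc1c(CO)c(-c2ccccc2)n2c1CS[C@@H]2c1ccccc1`, 52100 nM

Compound 3 holds the higher of the two numbers available. Among the compounds with values here, its nearest neighbour is compound 1, and the single measured step, a 52-fold higher number from compound 1 to compound 3 (1.72 log units; beyond the scatter), is large and beyond the scatter.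

Compound 4, `OCc1c(CO)c(-c2ccc(F)cc2)n2c1CS[C@@H]2c1ccccc1`, differs from compound 3 by fluoro in place of hydrogen on an aromatic carbon. Within the data shown here, no measured step concerns this change: the only step on record, a 52-fold higher number from compound 1 to compound 3 (1.72 log units; beyond the scatter), describes a different change and does not bear on it. For compound 4 in this assay, therefore, no step beyond the scatter is expected in either direction; the expected step is a 1.0-fold lower number from compound 3 to compound 4 (0.02 log units; within the scatter). Compound 4 is estimated at 50000 nM, between 20000 nM and 130000 nM.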

Compound 4, half-maximal inhibitory concentration: 44600 nM
Beside the measured number, compound 4's estimate is 1.1-fold (0.05 log units) above it; low and high end bracket the measured number.
By their numbers in this assay, from the lowest: compound 1; then compounds 4 and 3 (each within the scatter of the next).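

In this assay, phenyl to 4-fluorophenyl gives a 1.2-fold lower number from compound 3 to compound 4 (0.07 log units; within the scatter) and so leaves the number in place at this position on the aryl ring. Fluoro on the ring also does nothing to close the gap to the methyl compound, with a 45-fold higher number from compound 1 to compound 4 (1.65 log units; beyond the scatter) as the step. Nothing on hand accounts for either step.

Going by these compounds, whether an amine, a methoxy group or a carboxylic acid at this same ring position would move the number beyond the scatter remains open. So does whether an ethyl group in place of the methyl of compound 1 would keep its number.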